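Vero cytotoxicity notes: the phenyl to 4-bromophenyl step

This account rests on a few compounds, and the source may have more. Where it says the series, first, only, none or still open, it means among the compounds named here.

The series shares one core, seen in compound 1 `Cn1cc([N+](=O)[O-])cc1C(=O)NNC(=O)Nc1ccc([N+](=O)[O-])cc1` and compound 2 `Cn1cc([N+](=O)[O-])cc1C(=O)NNC(=O)Nc1ccccc1`. In an ADME assay on Vero cells (Chlorocebus sabaeus) for cytotoxicity, read by MTT assay, with a stated time of 72 h (a lower number here means a stronger inhibitor, a higher number a weaker inhibitor), compound 1 gives 402000 nM, and compound 2 gives 306000 nM. Going by the values given here, the only completed step, a 1.3-fold lower number from compound 1 to compound 2 (0.12 log units; within the scatter), consists of hydrogen in place of nitro on an aromatic carbon and changes nothing beyond the scatter. Among the compounds with values here, compound 2 therefore stands with the lowest number of the two, but its only neighbour, compound 1, sits within the scatter of it, so no order between them can be read.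

Compound 3 `Cn1cc([N+](=O)[O-])cc1C(=O)NNC(=O)Nc1ccc(Br)cc1` is not yet measured in this assay. Its difference from compound 2 is bromo in place of hydrogen on an aromatic carbon. The step from compound 1 to compound 2 is the only one that bears on this change, since it alters the same aromatic carbon of the same six-membered ring, and it was flat. Nothing in the measured pair suggests that a substituent at this place moves the number. For compound 3 the expectation is a step of about a 1.0-fold lower number from compound 2 to compound 3 (0.01 log units; within the scatter), that is, no change beyond the scatter. Compound 3 is estimated at 300000 nM, with a range from 150000 nM to 600000 nM.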

Compound 3, half-maximal inhibitory concentration: 602000 nM
Beside the measured number, compound 3's estimate is 2.0-fold (0.30 log units) below it, outside the stated range (above it).
By their numbers in this assay, from the lowest: compounds 2, 1 and 3 (each within the scatter of the next).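

In this assay, the step of a 2.0-fold higher number from compound 2 to compound 3 (0.29 log units; within the scatter) stays within the scatter, so bromo at this aromatic carbon, para to a large group, can be added to hydrogen and nitro as a replacement that gives no readable shift. The direct exchange of the two substituents, a 1.5-fold higher number from compound 1 to compound 3 (0.18 log units; within the scatter) as its printed step, is also within the scatter, which extends the flat reading from a single pair to all three compounds, with hydrogen, nitro and bromo at the same place. No order can be read among compounds 1, 2 and 3 in this assay, and no measured data are available here that could explain this flat result.

The compounds shown leave open whether a group of another kind at this place, such as an amine, a carboxylic acid or a longer alkyl chain, would give a step beyond the scatter. They also leave open whether bromo or nitro would give the same flat reading on another carbon of the six-membered aromatic ring, and whether a change in the shared core would move the number.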